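The compounds below may be only part of what the source reports. "The series", "measured", "known", "first", "only" and "open" are said of these compounds alone.

Measured compounds in the series:

- compound 1 `Cc1nn(-c2ccccc2I)c2c1C(c1ccc(Oc3ccccc3)cc1)SC(C)C(=O)N2`: 1300 nM
- compound 2 `Cc1ccc(-n2nc(C)c3c2NC(=O)[C@H](C)S[C@@H]3c2ccc(Oc3ccccc3)cc2)cc1`: 3400 nM
- compound 3 `Cc1ccccc1-n1nc(C)c2c1NC(=O)[C@H](C)S[C@@H]2c1ccc(Oc2ccc(C(=O)O)cc2)cc1`: "not active" (no number reported) (no number reported)

In an assay on isolated protein for agonist activity at Bile acid receptor (Homo sapiens), read by AlphaScreen, with a stated time of 30 min (on this read-out higher numbers stand for an effect only at larger amounts of compound and lower numbers for an effect already at smaller amounts), compound 1 gives 1300 nM and stands at the lowest of the two numbers available. Its nearest neighbour, compound 2, gives 3400 nM, a gap beyond the usual scatter. Compound 3 is recorded as "not active" (no number reported) in this assay, with no number to compare.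

The next compound to be measured is compound 4 `Cc1nn(-c2ccccc2Br)c2c1C(c1ccc(Oc3ccccc3)cc1)SC(C)C(=O)N2`. It differs from compound 1 in one place: bromo in place of iodo on an aromatic carbon. Among the measured compounds shown here, no pair of measured compounds with a single-point difference is available, so the size of this step cannot be read from the shared core; only the two numbers of compound 1 and compound 2 set the scale.

With one halogen exchanged for another of the same kind and nothing else altered, the change expected from compound 1 to compound 4 is a 1.2-fold higher number from compound 1 to compound 4 (0.09 log units; within the scatter), that is, none beyond the scatter, with a slight lean toward a higher number. Compound 4 is therefore estimated at 1600 nM, in the range 600 nM to 4500 nM.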

Compound 4, half-maximal effective concentration: 1800 nM
Compound 4: middle estimate off by 1.1-fold (0.05 log units), on the low side; the measured number falls inside the stated range.
By their numbers in this assay, from the lowest: compounds 1, 4 and 2 (each within the scatter of the next, the first and the last beyond it).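

In this assay, the exchange of iodo for bromo on an aromatic carbon ortho to a large group gives a 1.4-fold higher number from compound 1 to compound 4 (0.14 log units; within the scatter). Among the compounds shown here, this is the first single-point step, and it shows that these two halogens cannot be told apart at this position on the core of compound 1. No measured data bear on the reason for this result.

Open is whether a halogen is needed here at all, since the compounds shown do not reveal how the number responds to chloro, fluoro, a methoxy group, an amine or a nitrile on this aromatic carbon. Also open, as far as these compounds go, is whether the same exchange would read the same way with other changes elsewhere on the shared core, as this single step cannot answer that.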